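Chain homologation of the phenylsulfonamide in the cytotoxicity series

The compounds below may be only part of what the source reports. "The series", "measured", "known", "first", "only" and "open" are said of these compounds alone.

Among the compounds with values here, compound 3 `O=S(=O)(NCCNc1nccc(-c2c(-c3cccc(F)c3)nc3sccn23)n1)c1ccccc1` gives 19000 nM in a functional assay on SK-MEL-28 cells (Homo sapiens) for cytotoxicity, read by MTT assay (a lower number here means a stronger inhibitor, a higher number a weaker inhibitor), and stands at the highest number of the three measured so far. Within the data shown here, its nearest neighbour is compound 2 `O=S(=O)(NCCNc1nccc(-c2c(-c3cccc(F)c3)nc3sccn23)n1)c1ccc(F)cc1`, with 9450 nM in this assay; the only single-point step recorded in the set is a 2.0-fold higher number from compound 2 to compound 3 (0.30 log units; within the scatter). Compound 1 `COc1ccc(S(=O)(=O)NCCCNc2nccc(-c3c(-c4cccc(F)c4)nc4sccn34)n2)cc1` gives 8980 nM in this assay, a number beyond the scatter from compound 3, but the two differ in more than one place, so only the two values themselves can be compared.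

Compound 4 `O=S(=O)(NCCCNc1nccc(-c2c(-c3cccc(F)c3)nc3sccn23)n1)c1ccccc1` is obtained from compound 3 by the change (((phenylsulfonyl)amino)methyl in place of (phenylsulfonyl)amino on a saturated chain carbon, two bonds along the chain from a nitrogen on an aromatic ring). Among the measured compounds shown here, no measured pair isolates this change: the step from compound 2 to compound 3 concerns the aromatic fluoro, not the chain. Compound 1 carries the same three-carbon chain as compound 4 together with a methoxy on the sulfonyl aryl ring, and its value sits close to those of compounds 2 and 3, which suggests that the chain length alone does not move this assay beyond the scatter.

For compound 4 the expected step is a 1.5-fold lower number from compound 3 to compound 4 (0.16 log units; within the scatter), that is no change beyond the scatter, and the estimated value is 13000 nM with a range from 5000 nM to 32000 nM.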

Compound 4, half-maximal inhibitory concentration: 6850 nM
Estimate against measurement, compound 4: 1.9-fold (0.28 log units) above; low and high end bracket the measured number.
By their numbers in this assay, from the lowest: compounds 4, 1, 2 and 3 (each within the scatter of the next, the first and the last beyond it).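

Chain length in this assay can now be read on its own: ((phenylsulfonyl)amino)methyl in place of (phenylsulfonyl)amino on a saturated chain carbon, two bonds along the chain from a nitrogen on an aromatic ring, gives a 2.8-fold lower number from compound 3 to compound 4 (0.44 log units; beyond the scatter) and is a modest step, the first single-place step in the series beyond the scatter. On the longer chain, removing the methoxy from the sulfonyl aryl ring gives a 1.3-fold lower number from compound 1 to compound 4 (0.12 log units; within the scatter) and leaves the two compounds within the scatter. ((phenylsulfonyl)amino)methyl in place of ((4-fluorophenyl)sulfonyl)amino on a saturated chain carbon, two bonds along the chain from a nitrogen on an aromatic ring, gives a 1.4-fold lower number from compound 2 to compound 4 (0.14 log units; within the scatter), but chain and aromatic fluoro change together in this step, so it cannot be read as a single change. Nothing available bears on the reason for the chain step.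

Still open, going by these compounds, is whether a longer chain would extend this step, hold it or reverse it, since only one added chain carbon is covered here. Also open, on these data alone, is how a carboxylic acid or an amine on the sulfonyl aryl ring would read on the longer chain, and whether an aromatic fluoro there would give a step like the one seen on the shorter chain.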